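The compounds below may be only part of what the source reports. "The series", "measured", "known", "first", "only" and "open" are said of these compounds alone.

Compounds measured in a functional assay on SW1573 cells (Homo sapiens) for inhibition, read by sulforhodamine B assay, with a stated time of 48 h (a lower number here means a stronger inhibitor of growth, a higher number a weaker inhibitor of growth), so far:
compound 1, `COC(=O)[C@@]1(C)CCC=C2[C@@H]1CC[C@@H](C)[C@]2(C)Cc1c[nH]c2ccc(C(F)(F)F)cc12`, 14000 nM
compound 2, `COC(=O)[C@@]1(C)CCC=C2[C@@H]1CC[C@@H](C)[C@]2(C)Cc1c[nH]c2c(Br)cccc12`, 14000 nM
compound 3, `COC(=O)[C@@]1(C)CCC=C2[C@@H]1CC[C@@H](C)[C@]2(C)Cc1c(C)n(C(c2ccccc2)c2ccccc2)c2ccc(Cl)cc12`, > 100000 nM

Compound 1 and compound 2 give values that lie within the scatter of each other. For compound 3 the entry of > 100000 nM is a limit of this assay, not a number. Compound 3 therefore sits at the limit of > 100000 nM in this assay, at which 1 of the 3 values shown sits, the weakest end of what has been measured, with no numerical value to build a step on.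

Compound 4, `Cc1c(C[C@]2(C)C3=CCC[C@](C)(C(=O)O)[C@H]3CC[C@H]2C)c2cc(Cl)ccc2n1C(c1ccccc1)c1ccccc1`, differs from compound 3 in one place: hydrogen in place of methyl on an oxygen next to a carbonyl group. For the measured compounds named here, no pair of measured compounds shows this change, so its size in this assay is unknown. Compound 3 gives only a limit, so the step to compound 4 cannot come out as a measured number either. Compound 4 is expected to stay near that limit, and the expected step is a number no higher from compound 3 to compound 4 (the limit leaves the size open). Compound 4 is estimated at 100000 nM in this assay, within a range of 30000 nM to 300000 nM, and it is expected that this assay may again report only a limit.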

Compound 4, concentration for 50% growth inhibition: 13000 nM
Estimate against measurement, compound 4: 7.7-fold (0.89 log units) above; the whole stated range lies above it.
By their numbers in this assay, from the lowest: compounds 4, 1 and 2 (each within the scatter of the next). At a limit, above all of these: compound 3.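

Hydrogen in place of methyl on an oxygen next to a carbonyl group gives an at least 7.6-fold lower number from compound 3 to compound 4 (0.88 log units; beyond the scatter) in this assay, the first change in one place in this series with a readable effect. The read-out therefore responds at this position: methoxycarbonyl to carboxy turns a compound without a numerical value into one with a measured value. The true size of the step remains open because compound 3 gives only a limit of the assay: the limit of > 100000 nM in this assay, at which 1 of the 4 values shown sits.

The compounds shown leave open whether the same change would shift the values of compound 1 and compound 2 by a similar amount. They also leave open how a primary amide or a primary alcohol at this place would compare with the carboxy group of compound 4 in this assay.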